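The source may hold more compounds than are shown below. What is called first, only, known or untested is meant among the compounds shown, and "the series" means these compounds.

Working notes on the nitro-sulfone amide series and its cytotoxicity read-out.

Compound 1 `CS(=O)(=O)c1ccc(C(=O)N2CCC(C(=O)N3CCc4ccccc43)CC2)cc1[N+](=O)[O-]` carries a piperidine-linked amide to a 2,3-dihydro-1H-indol-1-yl group. In an ADME assay on HepG2 cells (Homo sapiens) for cytotoxicity, read by CellTiter-Glo and ATP content, with a stated time of 72 h (on this read-out higher numbers stand for an effect only at larger amounts of compound and lower numbers for an effect already at smaller amounts), compound 1 gives > 27000 nM, which is a limit of the assay and not a number. Compound 2 `CN(Cc1cccc(F)c1)C(=O)CCCNC(=O)c1ccc(S(C)(=O)=O)c([N+](=O)[O-])c1` in this assay likewise gives > 27000 nM, again a limit of the assay. Within the data shown here, compound 3 `CS(=O)(=O)c1ccc(C(=O)NCC(=O)N(Cc2ccccc2)Cc2ccccc2)cc1[N+](=O)[O-]` is the only member with a numerical read-out, giving 11900 nM in this assay. Where compound 1 stands can therefore be said only loosely: it sits at the limit of > 27000 nM in this assay, at which 2 of the 3 values shown sit, and no step between it and another measured compound can be sized.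

Compound 4 `CN(Cc1ccccc1F)C(=O)C1CCN(C(=O)c2ccc(S(C)(=O)=O)c([N+](=O)[O-])c2)CC1` is the next member. Relative to compound 1 the change is (2-fluorobenzyl)(methyl)amino in place of 2,3-dihydro-1H-indol-1-yl on a carbonyl carbon; the core and the piperidine amide stay unchanged. Among the measured compounds shown here, no measured step bears on such a change, so no direction beyond the scatter is expected in this assay for the step from compound 1 to compound 4, and the most likely outcome is that compound 4 also returns a limit. Compound 4 is accordingly estimated at 30000 nM, within 12000 nM to 80000 nM, an expected step that the limit leaves unreadable from compound 1 to compound 4.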

Compound 4, half-maximal effective concentration: > 27000 nM
Compound 4: no number, only a limit; the forecaster's own chance of this, stated with the estimate: 65%; the middle value is on the limit's open side.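

In this assay compound 4 gives > 27000 nM, a limit of the assay and not a number. Among these compounds, compound 1 is also a limit, so no step between compound 1 and compound 4 can be read: the limit of > 27000 nM in this assay, at which 3 of the 4 values shown sit. The compounds shown leave open how (2-fluorobenzyl)(methyl)amino and 2,3-dihydro-1H-indol-1-yl compare on a carbonyl carbon in this assay.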